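The compounds below may be only part of what the source reports. "The series", "measured", "known", "first", "only" and "open" are said of these compounds alone.

Measured compounds. Compound 1 `Nc1ncn(CCC2(N)OC(=O)C(OCc3ccccc3)=C2OCc2ccccc2)c(=O)n1` in a functional assay on MIA PaCa-2 cells (Homo sapiens) for inhibition, read by MTT assay, with a stated time of 72 h (a lower number here means a stronger inhibitor, a higher number a weaker inhibitor), gives > 100000 nM, which is a limit of the assay and not a number. Compound 2 `NC1(CCn2ncc(=O)[nH]c2=O)OC(=O)C(OCc2ccccc2)=C1OCc1ccccc1` in this assay gives > 100000 nM, likewise a limit and not a number.

Going by the values given here, compound 2 thus stands only at a limit, and the one further value shown is a limit as well; both sit at the limit of > 100000 nM in this assay, at which 2 of the 2 values shown sit. Among the compounds with values here, the single measured step, a step that the two limits leave unreadable from compound 1 to compound 2, is left unreadable by the two limits, so it yields neither a size nor a direction.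

Compound 3 `NC1(CCn2cc(F)c(=O)[nH]c2=O)OC(=O)C(OCc2ccccc2)=C1OCc1ccccc1` differs from compound 2 in one place: a group of 9 heavy atoms (4 carbon, 2 nitrogen, 2 oxygen, 1 fluorine; one six-membered aromatic ring with 2 hetero atoms) in place of a group of 8 heavy atoms (3 carbon, 3 nitrogen, 2 oxygen; one six-membered aromatic ring with 3 hetero atoms), on a saturated chain carbon, two bonds along the chain from a saturated ring carbon. Within the data shown here, no measured step bears readably on this change. For compound 3 in this assay no step beyond the scatter can be anticipated from the data, and the expected outcome is another limit. The estimate for compound 3 is 150000 nM, with a range from 30000 nM to 1000000 nM. The step this estimate implies, a step that the limit leaves unreadable from compound 2 to compound 3, is expected to be small.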

Compound 3, half-maximal inhibitory concentration: > 100000 nM
Compound 3: a limit, no number; the forecaster's own chance of this, stated with the estimate: 80%; the middle value is on the limit's open side.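

In this assay compound 3 gives > 100000 nM as a limit of the assay and not a number. Going by these compounds alone, no step among compound 1, compound 2 and compound 3 can be read, as all three values stand at one limit: the limit of > 100000 nM in this assay, at which 3 of the 3 values shown sit. The compounds shown leave open how these ring groups on the chain would rank, since none gives a measured half-maximal inhibitory concentration.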